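Triazole substituent swap on a trifluoromethyl chromene ester core

The source may report more compounds than this note shows. Statements on the series, on what has been measured and on what is new or still open speak of the compounds shown alone.

Measured compounds:
compound 1, `CCOC(=O)C1=Cc2ccccc2OC1(OCc1cn(CC(=O)NC2CCCCC2)nn1)C(F)(F)F`, 11400 nM
compound 2, `CCOC(=O)C1=Cc2ccccc2OC1(OCc1cc(-c2ccc(Br)cc2)no1)C(F)(F)F`, 52300 nM

In a functional assay on HeLa cells (Homo sapiens) for inhibition, read by MTT assay, with a stated time of 24 h (a lower number here means a stronger inhibitor, a higher number a weaker inhibitor), compound 1 gives 11400 nM. In this assay compound 2 gives 52300 nM. Of the two numbers shown, compound 1 has the lower one, and the gap to compound 2 is wider than the usual scatter of such measurements. Among the measured compounds shown here, the two compounds differ in more than one place, so no single step between them is set out here; only what their two values show can be stated.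

The unmeasured compound 3, `CCOC(=O)C1=Cc2ccccc2OC1(OCc1cn(-c2cccc(C(F)(F)F)c2)nn1)C(F)(F)F`, shares the core of compound 1. The change from compound 1 to compound 3 is the following: 3-(trifluoromethyl)phenyl in place of (cyclohexylcarbamoyl)methyl on an aromatic nitrogen. The group that leaves carries one hydrogen-bond donor and one acceptor, while the entering 3-(trifluoromethyl)phenyl carries none. No step of this kind is shown among the measured compounds, so the direction cannot be read from data; compound 3 is expected to sit close to compound 1, with a step of a 1.3-fold higher number from compound 1 to compound 3 (0.12 log units; within the scatter) that is estimated to be small and within or near the scatter. For compound 3 the estimate in this assay is 15000 nM, expected between 5000 nM and 50000 nM.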

Compound 3, half-maximal inhibitory concentration: > 150000 nM
Compound 3 was reported as a limit (the forecaster's own chance of this, stated with the estimate: 10%); middle value at least 10-fold (1.00 log units) from the limit.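

The group on this aromatic nitrogen matters strongly in this assay: 3-(trifluoromethyl)phenyl in place of (cyclohexylcarbamoyl)methyl, with the same number of heavy atoms and the shared core kept, gives an at least 13-fold higher number from compound 1 to compound 3 (1.11 log units; beyond the scatter). Among the compounds shown here, this is the first step that can be read at a single place, and it shows that the value of compound 1 does not survive this exchange, even though the size of the group, counted in heavy atoms, stays the same. Compound 3 has no exact number, and its entry is a limit of the assay, so the step gives only a lower bound on the size of the change: the limit of > 150000 nM in this assay, at which 1 of the 3 values shown sits.

The exchange removes the amide with its hydrogen-bond donor and acceptor and also replaces the non-aromatic ring with an aromatic one, and the compounds shown do not tell these changes apart. A (phenylcarbamoyl)methyl group, which keeps the amide and carries an aromatic ring, or a cyclohexyl group set directly on the nitrogen, would separate them, and neither is among the compounds shown here.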